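A few compounds are considered here, and "the series" means these few. Any claim that something is new, unique, unknown or untested is made for them only; others in the source may bear on it.

Measured so far in a functional assay on ECa-109 cells (Homo sapiens) for cytotoxicity, read by MTT assay, with a stated time of 48 h (on this read-out lower numbers stand for stronger inhibition and higher numbers for weaker inhibition), all three being limits and not numbers:

- compound 1 `COc1ccc(-c2cn(C(=O)Nc3cc(OC)c(OC)c(OC)c3)c(=O)n2-c2cc(OC)c(OC)c(OC)c2)cc1`: > 50000 nM
- compound 2 `COc1ccc(-c2cn(C(=O)Nc3cc(OC)c(OC)c(OC)c3)c(=O)n2-c2cc(OC)c(OC)c(OC)c2)cc1OC`: > 50000 nM
- compound 3 `COc1cc(-n2c(-c3ccccc3)cn(C(C)=O)c2=O)cc(OC)c1OC`: > 50000 nM

Compound 3 has no number, only the limit > 50000 nM. Among the compounds with values here, the series so far shows (the limit of > 50000 nM in this assay, at which 3 of the 3 values shown sit).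

The next compound is compound 4 `COc1ccc(-c2cn(C(C)=O)c(=O)n2-c2cc(OC)c(OC)c(OC)c2)cc1OC`. The change is 3,4-dimethoxyphenyl in place of phenyl on an aromatic carbon, two ring bonds from the ring atom that bears an acetyl group: 3,4-dimethoxyphenyl in place of phenyl on an aromatic carbon.

Within the data shown here, the one measured step that bears on this is a step that the two limits leave unreadable from compound 1 to compound 2, which also adds methoxy in place of hydrogen on an aromatic carbon. Both of its ends are limits, so it offers no size to carry over. It gives no sign of a gain, though a hidden one cannot be excluded. No shift beyond the scatter is therefore expected in this assay, in either direction, and the most likely report is again a limit.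

The expected step is a number no higher from compound 3 to compound 4 (the limit leaves the size open).

For compound 4 the estimated value is 50000 nM, with an expected range from 15000 nM to 80000 nM.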

Compound 4, half-maximal inhibitory concentration: > 50000 nM
Compound 4 gave a limit, no number; the forecaster's own chance of this, stated with the estimate: 85%; the middle value sits exactly at the limit.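

Compound 3 and compound 4 are both limits and not numbers in this assay, so no step can be read between them, and the series stands as follows: the limit of > 50000 nM in this assay, at which 4 of the 4 values shown sit.

The compounds shown leave open which change to the shared core, if any, would give a measurable value in this assay.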